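A few compounds are considered here, and "the series" means these few. Any claim that something is new, unique, unknown or untested is made for them only; others in the source may bear on it.

Measured so far in an assay on HEK293 cells for inhibition of transient receptor potential cation channel subfamily M member 8 (Homo sapiens), read by FLIPR, with stated times of 5 min and 3 min; on this read-out lower numbers stand for stronger inhibition and higher numbers for weaker inhibition:
Compound 1 `CCOC(=O)c1cnc(-c2ccccc2)s1` gives > 100000 nM, a limit of the assay.
Compound 2 `CCOC(=O)c1sc(-c2ccccc2)nc1N` gives > 100000 nM, also a limit.
Compound 3 `CCn1nnc(-c2sc(-c3c(Cl)cccc3Cl)nc2O)n1` gives 16500 nM.

Compound 2 thus stands at the limit of > 100000 nM in this assay, at which 2 of the 3 values shown sit, so only a limit, not a number, is known for it. Both ends of the step that the two limits leave unreadable from compound 1 to compound 2 are limits, so its size is not readable. Compound 4 `CCOC(=O)c1sc(-c2ccccc2)nc1CO` differs from compound 2 by hydroxymethyl in place of amino on an aromatic carbon. Among the measured compounds shown here, no measured step touches this change, so nothing here sets a direction or a size for it. The step of a number no higher from compound 2 to compound 4 (the limit leaves the size open) is therefore expected to be small or not readable. Compound 4 is estimated at 100000 nM, within 30000 nM to 300000 nM, and most likely again reported only as a limit.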

Compound 4, half-maximal inhibitory concentration: > 100000 nM
Compound 4: a limit, no number; the forecaster's own chance of this, stated with the estimate: 70%; the middle value lies on the limit itself.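

No step can be read among compound 1, compound 2 and compound 4, as each gives only a limit, not a number: the limit of > 100000 nM in this assay, at which 3 of the 4 values shown sit.

The compounds shown leave open whether hydrogen, amino or hydroxymethyl on this aromatic carbon makes any difference in this assay.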